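The source may report more compounds than this note shows. Statements on the series, on what has been measured and on what is new or still open speak of the compounds shown alone.

Compound 1 `COc1ccccc1C(C1=C(O)C(=O)c2ccccc2C1=O)c1c[nH]c2ccccc12`: > 200000 nM
Compound 2 `Cc1[nH]c2ccccc2c1C(C1=C(O)C(=O)c2ccccc2C1=O)c1ccc(Cl)cc1`: 14300 nM
Compound 3 `O=C1C(O)=C(C(c2ccc(Cl)cc2)c2c[nH]c3ccccc23)C(=O)c2ccccc21`: 45800 nM

The three measured compounds share one core and differ in the aryl group on a saturated chain carbon bound to an aromatic carbon and a double-bonded ring carbon, and in one case in a methyl on an aromatic carbon. In a functional assay on ECa-109 cells (Homo sapiens) for cytotoxicity, read by MTT assay, with a stated time of 48 h (a higher number here means a weaker inhibitor, a lower number a stronger inhibitor), compound 1 gives > 200000 nM, which is a limit of the assay rather than a number. Compound 3 gives 45800 nM in this assay. Compound 2 gives 14300 nM in this assay. So compound 1 stands at the limit of > 200000 nM in this assay, at which 1 of the 3 values shown sits, the weakest position among the three, with no exact number known.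

Compound 4 `COc1cccc(C(C2=C(O)C(=O)c3ccccc3C2=O)c2c[nH]c3ccccc23)c1` has not yet been measured. It differs from compound 1 by 3-methoxyphenyl in place of 2-methoxyphenyl on a saturated chain carbon bound to an aromatic carbon and a double-bonded ring carbon. Of the measured steps, an at least 4.3-fold lower number from compound 1 to compound 3 (0.64 log units; beyond the scatter) shows that exchanging the 2-methoxyphenyl group for another aryl group can lower the number at least modestly, while a 3.2-fold higher number from compound 2 to compound 3 (0.51 log units; beyond the scatter) concerns a methyl on an aromatic carbon and does not bear directly on this change. Moving the methoxy group within the phenyl ring is a smaller change than the one seen from compound 1 to compound 3, so a modest lowering, if any, is expected here: an at least 1.6-fold lower number from compound 1 to compound 4 (0.22 log units; that floor lies within the scatter). Compound 4 is therefore estimated at 120000 nM in this assay, within a range from 30000 nM to 300000 nM, with a real chance that only a limit is again reported.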

Compound 4, half-maximal inhibitory concentration: 40000 nM
Compound 4: the middle estimate sits 3.0-fold (0.48 log units) above what was measured, within the range that was stated.
By their numbers in this assay, from the lowest: compound 2; then compounds 4 and 3 (each within the scatter of the next). At a limit, above all of these: compound 1.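

Swapping 2-methoxyphenyl for 3-methoxyphenyl keeps the same atoms and only rearranges them, yet in this assay it gives an at least 5.0-fold lower number from compound 1 to compound 4 (0.69 log units; beyond the scatter) and so moves the compound off the assay limit. Going by these compounds alone, at this place on the saturated chain carbon, then, where the methoxy sits on the phenyl ring matters, and the earlier compounds could not show this because compound 1 and compound 3 carry different groups on that ring. As far as these compounds go, compound 3 and compound 4 cannot be told apart, since a 1.1-fold lower number from compound 3 to compound 4 (0.06 log units; within the scatter) and a chlorine-bearing group and a methoxy-bearing group read alike here, while compound 1 remains a limit, so the full size of its step is unknown: (the limit of > 200000 nM in this assay, at which 1 of the 4 values shown sits).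

From the compounds shown here alone, what a plain phenyl group, or a phenyl ring carrying an amine or a carboxylic acid, would do at this place remains open, so the reach of this reading beyond these aryl groups is unknown. Also open, going by these compounds, is whether the methyl on an aromatic carbon that separates compound 2 from compound 3 would shift compound 4 in the same way.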